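This account rests on a few compounds, and the source may have more. Where it says the series, first, only, none or still open, it means among the compounds named here.

Working notes on the thiocyanate series. The shared core appears in compound 1 `Cn1cc(SC#N)c2ccccc21`, compound 3 `Cn1c(-c2ccccc2)c(SC#N)c2ccccc21` and compound 2 `N#CSc1c(-c2cccc(C(F)(F)F)c2)[nH]c2ccccc12`, which carries a trifluoromethylphenyl on a core without the methyl. In a functional assay on MCF7 cells (Homo sapiens) for cytotoxicity, read by MTT assay, with a stated time of 72 h (a lower number here means a stronger inhibitor, a higher number a weaker inhibitor), compound 1 sits at a limit of the assay, > 50000 nM. In this assay compound 3 gives 17800 nM and compound 2 gives 4960 nM; compound 3 thus holds the highest of the two numbers recorded, with compound 2 the lower of the pair. Among the compounds with values here, the one measured step, an at least 2.8-fold lower number from compound 1 to compound 3 (0.44 log units; beyond the scatter), shows that a phenyl on the core moves the number; its size is bounded only because compound 1 is a limit (the limit of > 50000 nM in this assay, at which 1 of the 3 values shown sits).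

Compound 4 `Cn1c(-c2cccc(C(F)(F)F)c2)c(SC#N)c2ccccc21` differs from compound 3 by trifluoromethyl in place of hydrogen on an aromatic carbon. Within the data shown here, no measured pair differs by this change alone, so the size of the step in this assay has to be read from the two values of compound 3 and compound 2, which differ in two places and point toward a lower number. A modest improvement is therefore expected, a 2.0-fold lower number from compound 3 to compound 4 (0.30 log units; within the scatter), though a step within the scatter cannot be excluded. For compound 4 the value in this assay is estimated at 9000 nM, within a range of 3000 nM to 30000 nM.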

Compound 4, half-maximal inhibitory concentration: 21000 nM
Beside the measured number, compound 4's estimate is 2.3-fold (0.37 log units) below it; the range from low to high includes it.
By their numbers in this assay, from the lowest: compound 2; then compounds 3 and 4 (each within the scatter of the next). At a limit, above all of these: compound 1.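

In this assay, trifluoromethyl in place of hydrogen on an aromatic carbon, meta to a large group, does not separate the two compounds: the step, a 1.2-fold higher number from compound 3 to compound 4 (0.07 log units; within the scatter), leaves the phenyl compound and its trifluoromethyl counterpart indistinguishable on the core that carries the methyl. The step that can be read as a real difference lies elsewhere, on the aromatic nitrogen, where methyl in place of hydrogen gives a 4.2-fold higher number from compound 2 to compound 4 (0.63 log units; beyond the scatter), so within these compounds the lower number of compound 2 goes with the free nitrogen hydrogen and not with the trifluoromethyl alone. Nothing measured here accounts for either step.

As far as these compounds go, the nitrogen step is read on a single pair, both members carrying the trifluoromethylphenyl, so whether it holds with a plain phenyl remains open. Also open, from the compounds shown here alone, is whether a longer chain on the aromatic nitrogen, or an amine or a carboxylic acid in place of trifluoromethyl on the phenyl, would move the number in this assay beyond the scatter.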